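A few compounds are considered here, and "the series" means these few. Any claim that something is new, unique, unknown or untested is made for them only; others in the source may bear on it.

Compounds measured in a functional assay on HCT-116 cells (Homo sapiens) for inhibition, read by MTT assay, with a stated time of 48 h; a higher number here means a weaker inhibitor, a lower number a stronger inhibitor:

- Compound 1 `Cc1c(NC(=O)CN2C(=O)S/C(=C\c3ccc(Br)cc3)C2=O)c(=O)n(-c2ccccc2)n1C`: 7840 nM
- Compound 2 `Cc1c(NC(=O)CN2C(=O)S/C(=C\c3ccc(Cl)cc3)C2=O)c(=O)n(-c2ccccc2)n1C`: 23000 nM

Compound 2 has the higher of the two numbers, which makes it the weaker inhibitor of this pair. The gap to compound 1 lies beyond the usual scatter.

Compound 3 `Cc1cc(C)c(/C=C2\SC(=O)N(CC(=O)Nc3c(C)n(C)n(-c4ccccc4)c3=O)C2=O)c(C)c1` has not yet been measured. It carries 2,4,6-trimethylphenyl in place of 4-chlorophenyl on a double-bonded chain carbon bound to a double-bonded ring carbon.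

Within the data shown here, only one measured step bears on this change: a 2.9-fold higher number from compound 1 to compound 2 (0.47 log units; beyond the scatter). That step, chloro in place of bromo on an aromatic carbon, was modest. It touched the same aromatic group, but it swapped only one substituent, whereas compound 3 loses the chloro and gains three methyl groups. It therefore gives a rough idea of size and little guidance on direction.

In this assay, no step beyond the scatter is expected, and the estimated change is a 1.4-fold lower number from compound 2 to compound 3 (0.16 log units; within the scatter). The data cannot exclude a larger move in either direction, so the range is kept wide.

For compound 3 the expected value is 16000 nM, with an estimated range from 5000 nM to 50000 nM.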

Compound 3, half-maximal inhibitory concentration: 56200 nM
Compound 3: the middle estimate sits 3.5-fold (0.55 log units) below what was measured, and the stated range ends below it.
By their numbers in this assay, from the lowest: compound 1; then compound 2; then compound 3.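

In this assay, putting 2,4,6-trimethylphenyl in place of 4-chlorophenyl gives a 2.4-fold higher number from compound 2 to compound 3 (0.39 log units; beyond the scatter), and putting it in place of 4-bromophenyl gives a 7.2-fold higher number from compound 1 to compound 3 (0.86 log units; beyond the scatter). The earlier pair only exchanged one halogen for another on the aromatic ring, whereas these steps show that removing the halogen altogether and adding three methyl groups at this position also shifts the number upward, leaving compound 3 as the weakest inhibitor of the three. Nothing available explains this rise, so the result stands as an observation without a known cause.

Compound 3 differs from compound 1 and compound 2 in two ways at once, since it both lacks a halogen and carries three methyl groups, so the effect of each cannot be separated. A plain phenyl ring, a phenyl ring with a single methyl group, and rings carrying a methoxy group, an amine or a carboxylic acid are not among the compounds shown, so it remains open how this position responds to such groups.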